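This account rests on a few compounds, and the source may have more. Where it says the series, first, only, none or still open, it means among the compounds named here.

Measured in a functional assay on the whole organism (strain Sprague-Dawley) for inhibition, with Rattus norvegicus as the target, with a stated time of 10 min; on this read-out higher numbers stand for an effect only at larger amounts of compound and lower numbers for an effect already at smaller amounts:
- compound 1 `CCOC(=O)c1cnc(-c2ccccc2OC)[nH]c1=O`: 10 mg/kg
- compound 2 `CCOC(=O)c1cnc(-c2ccc(OC)cc2)[nH]c1=O`: 30 mg/kg

Of these two, compound 2 stands at the higher number, 30 mg/kg, so it needs the larger dose. The gap to compound 1 at 10 mg/kg lies beyond the scatter. Compound 3 `CCOC(=O)c1cnc(-c2ccc(OC)cc2OC)[nH]c1=O` differs from compound 2 by methoxy in place of hydrogen on an aromatic carbon, ortho to a large group and meta to a methoxy group. Compound 1 at 10 mg/kg also carries a methoxy ortho to a large group, so a move to a lower number in this assay is expected, beyond the scatter. For the measured compounds named here, the expected change is a 2.5-fold lower number from compound 2 to compound 3 (0.40 log units; beyond the scatter), resting on only two measured compounds. For compound 3 the estimated value is 12 mg/kg, with an expected range of 4 mg/kg to 35 mg/kg.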

Compound 3, dose for 50% inhibition: 5 mg/kg
Beside the measured number, compound 3's estimate is 2.4-fold (0.38 log units) above it; the range from low to high includes it.
By their numbers in this assay, from the lowest: compounds 3 and 1 (each within the scatter of the next); then compound 2.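

In this assay the aromatic carbon ortho to a large group responds to methoxy in place of hydrogen even with the other methoxy already present, giving a 6.0-fold lower number from compound 2 to compound 3 (0.78 log units; beyond the scatter) and showing that this position matters on the shared core. The same kind of change made on compound 1 gives a 2.0-fold lower number from compound 1 to compound 3 (0.30 log units; within the scatter) and cannot be told apart from no change, so the other methoxy shows no readable contribution once a methoxy sits ortho to a large group. No supporting measurement bears on why the dose shifts in this way.

Open, as far as these compounds go, is whether the shift belongs to methoxy itself or would also follow from fluorine, an amine or a longer ethoxy chain on the same carbon. Also open, from the compounds shown here alone, is how the series behaves with a carboxylic acid in place of the ethyl ester.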